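This account rests on a few compounds, and the source may have more. Where it says the series, first, only, none or still open, it means among the compounds named here.

Compound 1 `O=C1C=COC(/C=C/c2ccccc2)C1` and compound 2 `COc1ccc(/C=C/C2CC(=O)C=CO2)cc1` share one core, while compound 3 `COc1ccc(/C=C/c2cc(=O)cco2)cc1` and compound 4 `COc1ccc(/C=C/c2cc(=O)cco2)cc1OC` share another; the difference between the two cores is not broken down here. In a functional assay on U-251 cells (Homo sapiens) for inhibition, read by sulforhodamine B assay, with a stated time of 48 h (on this read-out lower numbers stand for stronger inhibition of growth and higher numbers for weaker inhibition of growth), compound 1 gives 122 uM, compound 2 gives 152 uM and compound 3 gives 278 uM. Compound 2 differs from compound 1 by methoxy in place of hydrogen on an aromatic carbon, and this change made a 1.2-fold higher number from compound 1 to compound 2 (0.10 log units; within the scatter). Compound 4 differs from compound 3 by methoxy in place of hydrogen on an aromatic carbon. This is the same kind of change, though the entering group sits in a different surrounding: in compound 2 it stands para to a group of 9 heavy atoms, whereas in compound 4 it stands ortho to a methoxy group and meta to a group of 9 heavy atoms. Compound 4 has not yet been tested in this assay. Because the earlier step of a 1.2-fold higher number from compound 1 to compound 2 (0.10 log units; within the scatter) stayed within the scatter, a similarly small step is expected here, namely a 1.1-fold higher number from compound 3 to compound 4 (0.03 log units; within the scatter). The number for compound 4 in this assay is therefore estimated at 300 uM, most likely falling between 150 uM and 600 uM.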

Compound 4, concentration for growth inhibition (reported as GI): 339 uM
Compound 4: middle estimate off by 1.1-fold (0.05 log units), on the low side, within the range that was stated.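

In this assay, putting methoxy in place of hydrogen on an aromatic carbon gave a 1.2-fold higher number from compound 3 to compound 4 (0.09 log units; within the scatter). Set beside the earlier case, the change behaves alike on both cores, and the two steps do not differ: the same change on two cores in this assay, a 1.2-fold higher number (0.10 log units; within the scatter) from compound 1 to compound 2 and a 1.2-fold higher number (0.09 log units; within the scatter) from compound 3 to compound 4, 1.0-fold (0.01 log units) apart, within the scatter of two such steps This shows that, for these two pairs, adding a methoxy group moved the number very little on either core, so the small size of the step carried across; it does not show that methoxy has any real effect on growth inhibition, as each step on its own stays within the scatter, and two pairs are too few to set a rule for the series.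

The compounds shown leave open whether a different group on the aromatic ring, such as an amine, a carboxylic acid or a longer chain, would give a larger step. They also leave open whether such a step would carry from one core to the other as the methoxy step does.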